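Aryl change on the aromatic nitrogen: compound 3 to compound 4

The source may hold more compounds than are shown below. What is called first, only, known or untested is meant among the compounds shown, and "the series" means these compounds.

Measured compounds:
- Compound 1, `Cc1ccccc1-n1nncc1CN1C(=O)C2(C(C#N)=C(N)Oc3c2c2nc4ccccc4nc2c2ccccc32)c2ccccc21`, in a functional assay on A549 cells (Homo sapiens) for antiproliferative activity, read by MTT assay, with a stated time of 48 h (a higher number here means a weaker inhibitor, a lower number a stronger inhibitor), compound 1 gives > 50000 nM, a limit of the assay and not a number.
- Compound 2, `N#CC1=C(N)Oc2c(c3nc4ccccc4nc3c3ccccc23)C12C(=O)N(Cc1cnnn1-c1ccc(Cl)cc1)c1ccccc12`, in this assay compound 2 gives > 50000 nM, again a limit and not a number.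
- Compound 3, `N#CC1=C(N)Oc2c(c3nc4ccccc4nc3c3ccccc23)C12C(=O)N(Cc1cnnn1-c1ccccc1Cl)c1ccccc12`, in this assay compound 3 gives 42600 nM.

Compound 3 holds the only number shown; the other two values sit at the limit of > 50000 nM in this assay, at which 2 of the 3 values shown sit. The steps into compound 3 are an at least 1.1-fold lower number from compound 1 to compound 3 (0.06 log units; that floor lies within the scatter) and an at least 1.1-fold lower number from compound 2 to compound 3 (0.06 log units; that floor lies within the scatter); both are floors, and each lies within the scatter. The step from compound 1 to compound 2 is not readable because both values are limits.

Compound 4, `N#CC1=C(N)Oc2c(c3nc4ccccc4nc3c3ccccc23)C12C(=O)N(Cc1cnnn1-c1cccc(Br)c1)c1ccccc12`, has not been measured. Its difference from compound 3 is 3-bromophenyl in place of 2-chlorophenyl on an aromatic nitrogen. The measured steps that bear on it are the two aryl changes on the aromatic nitrogen leading to compound 3, and neither shows a movement beyond the scatter. No step beyond the scatter is therefore expected in this assay, and a value at or near the limit is as likely as a number.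

Compound 4 is expected to give about 45000 nM in this assay, with a range from 15000 nM to 150000 nM. The expected step is a 1.1-fold higher number from compound 3 to compound 4 (0.02 log units; within the scatter).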

Compound 4, half-maximal inhibitory concentration: > 50000 nM
Compound 4: no number, only a limit; the forecaster's own chance of this, stated with the estimate: 55%; middle value at least 1.1-fold (0.04 log units) from the limit.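

In this assay compound 4 gives > 50000 nM, a limit of the assay and not a number. On the aromatic nitrogen, the change to 3-bromophenyl gives an at least 1.1-fold higher number from compound 3 to compound 4 (0.06 log units; that floor lies within the scatter), so a bromine-bearing aryl group is now covered at this position, but the data do not separate compound 4 from compound 3; the steps to compound 4 from compound 1 and from compound 2 cannot be read, as both ends of each are limits. With this result, the series of aryl groups on this nitrogen still has only one number, that of compound 3, and the readings gather at one value: the limit of > 50000 nM in this assay, at which 3 of the 4 values shown sit.

Compound 4 changes both the halogen and its place on the phenyl ring in a single step, so the effect of each remains unresolved, and 2-bromophenyl or 3-chlorophenyl on the same nitrogen would separate the two. Also open, on these data alone, is whether any group at this position, such as a phenyl ring carrying an amine or a carboxylic acid, gives a number clearly below the limit in this assay.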